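Swapping Methoxy for Cyano on a Nitrophenol Enone

The source may report more compounds than this note shows. Statements on the series, on what has been measured and on what is new or still open speak of the compounds shown alone.

Compound 1 `COc1ccc(C(=O)/C(=C\c2ccc(O)c([N+](=O)[O-])c2)SCc2ccc(Br)cc2)cc1`: 10000 nM
Compound 2 `O=C(/C(=C\c1ccc(O)c([N+](=O)[O-])c1)SCc1ccccc1Cl)c1ccc(Cl)cc1`: 10000 nM

Of the compounds shown here, two have so far been tested in a functional assay on DU-145 cells (Homo sapiens) for inhibition, read by trypan blue exclusion, with a stated time of 96 h; a lower number here means a stronger inhibitor of growth, a higher number a weaker inhibitor of growth. Compound 1 gives 10000 nM, and compound 2 gives 10000 nM. The two values are the same at the digits recorded, so compound 1 sits level with compound 2, and their gap lies within the scatter; nothing can be said about an order between them.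

Compound 3 `N#Cc1ccc(C(=O)/C(=C\c2ccc(O)c([N+](=O)[O-])c2)SCc2ccc(Br)cc2)cc1` has not yet been measured. It differs from compound 1 in one place: cyano in place of methoxy on an aromatic carbon. Within the data shown here, no step between measured compounds shows the effect of this exchange, so no directly comparable change is available. Given that compound 1 and compound 2 both sit at the same value in this assay despite different groups on both aryl rings, the expectation is that this exchange also changes little, with no step beyond the scatter in either direction. Compound 3 is therefore expected to give about 10000 nM in this assay, between 4000 nM and 25000 nM. That corresponds to an expected step of no change at the digits printed from compound 1 to compound 3 (within the scatter).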

Compound 3, concentration for 50% growth inhibition: 10000 nM
For compound 3 middle estimate and measured number coincide at the digits printed; the range from low to high includes it.
By their numbers in this assay, from the lowest: compounds 1, 2 and 3 (each within the scatter of the next).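

Cyano in place of methoxy on the aromatic carbon gives no change at the digits printed from compound 1 to compound 3 (within the scatter) in this assay and is the first reading of a single exchange in this series. Compound 1 and compound 2 differ in more than one place, so their matching values could not isolate any one group, whereas only the change from 4-methoxyphenyl to 4-cyanophenyl separates compound 1 from compound 3. At this position, these two groups, which have the same count of heavy atoms and of hydrogen-bond acceptors, cannot be told apart in this read-out, and nothing measured here bears on the reason for that.

From the compounds shown here alone, what remains open is whether a quite different group on this aromatic carbon, such as an amine or a carboxylic acid, would move the number beyond the scatter. One exchange on one background also leaves open whether cyano and methoxy would match in the same way when the rest of compound 1 is changed, for example when the bromine on the other ring is replaced by a longer chain.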